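The source may hold more compounds than are shown below. What is called first, only, known or untested is meant among the compounds shown, and "the series" means these compounds.

Of the compounds shown here, two of one shared core have been measured. Compound 1, `CN(C)CCn1c(=O)c(=Cc2ccc(F)c(F)c2)s/c1=C1\C(=O)Nc2ccc(F)cc21`, and compound 2, `CN(C)CCn1c(=O)c(=Cc2ccc(O)cc2)s/c1=C1\C(=O)Nc2ccc(Cl)cc21`, differ in two places at once, so their numbers can only be compared, not traced to one change. In a functional assay on MDA-MB-231 cells (Homo sapiens) for inhibition, read by MTT assay, with a stated time of 72 h (on this read-out lower numbers stand for stronger inhibition and higher numbers for weaker inhibition), compound 1 gives 9480 nM. In this assay compound 2 gives 3250 nM, the lowest of the two numbers and beyond the scatter from compound 1.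

Compound 3, `CN(C)CCn1c(=O)c(=Cc2ccc(O)cc2)s/c1=C1\C(=O)Nc2ccc(F)cc21`, carries one change against compound 2: fluoro in place of chloro on an aromatic carbon. Within the data shown here, no measured pair shows this single exchange on its own, so the size of the step rests on the surrounding numbers only. Compound 1, which also holds fluoro at this place, sits higher than compound 2, which hints at a small rise rather than a drop. The step from compound 2 to compound 3 is therefore expected to be a 1.5-fold higher number from compound 2 to compound 3 (0.19 log units; within the scatter), a modest weakening that may stay within the scatter. Compound 3 is estimated at 5000 nM, within a range from 2000 nM to 12500 nM.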

Compound 3, half-maximal inhibitory concentration: 4200 nM
Compound 3: the middle estimate sits 1.2-fold (0.08 log units) above what was measured, within the range that was stated.
By their numbers in this assay, from the lowest: compounds 2 and 3 (each within the scatter of the next); then compound 1.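

In this assay, fluoro in place of chloro on this aromatic carbon gives a 1.3-fold higher number from compound 2 to compound 3 (0.11 log units; within the scatter), so this single exchange, now seen on its own, separates the two compounds by no more than ordinary scatter. Among these compounds, compound 3 also shares its fluoro with compound 1, which makes the other place readable for the first time: 4-hydroxyphenyl in place of 3,4-difluorophenyl gives a 2.3-fold lower number from compound 1 to compound 3 (0.35 log units; beyond the scatter), a modest step beyond the scatter. No measurement shown here explains either step.

As far as these compounds go, only chloro and fluoro appear on this aromatic carbon, so the effect of a bromo or methoxy group there remains open. From the compounds shown here alone, at the other place, it also remains open how a 4-aminophenyl or 4-methoxyphenyl group would compare with 4-hydroxyphenyl.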